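Removing the amino group from compound 2

The source may hold more compounds than are shown below. What is called first, only, known or untested is meant among the compounds shown, and "the series" means these compounds.

Measured in an ADME assay on microsomes (Mus musculus) for metabolic stability, read by LC-MS, using NADPH, with a stated time of 1 h, tested at 1 uM; on this read-out lower numbers stand for slow clearance and higher numbers for fast clearance:
- compound 1 `O=c1ccc(-c2ccc3cn[nH]c3c2)cn1Cc1cccc(C(F)(F)F)c1`: 63 mL.min-1.g-1
- compound 2 `Nc1n[nH]c2cc(-c3ccc(=O)n(Cc4cccc(F)c4)c3)ccc12`: < 10 mL.min-1.g-1 (a limit, not a number)

Compound 2 gives only a limit in this assay, as this shows: the limit of < 10 mL.min-1.g-1 in this assay, at which 1 of the 2 values shown sits. Compound 3 `O=c1ccc(-c2ccc3cn[nH]c3c2)cn1Cc1cccc(F)c1` has hydrogen in place of amino on an aromatic carbon. Among the measured compounds shown here, no measured pair isolates this change. Compound 1 also lacks the amino group and gives 63 mL.min-1.g-1, so a rise beyond the scatter is expected in this assay. The estimated change is an at least 4.0-fold higher number from compound 2 to compound 3 (0.60 log units; beyond the scatter). For compound 3 the estimate is 40 mL.min-1.g-1, with an expected range from 15 mL.min-1.g-1 to 90 mL.min-1.g-1.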

Compound 3, intrinsic clearance in microsomes: 160 mL.min-1.g-1
Estimate against measurement, compound 3: 4.0-fold (0.60 log units) below; the measured number lies above the stated range.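

In this assay the amino group now has a step of its own: hydrogen in place of amino on an aromatic carbon gives an at least 16-fold higher number from compound 2 to compound 3 (1.20 log units; beyond the scatter) as a large step. That step is only a floor, since the number for compound 2 is a limit: the limit of < 10 mL.min-1.g-1 in this assay, at which 1 of the 3 values shown sits. Fluoro in place of trifluoromethyl on an aromatic carbon also matters, giving a 2.5-fold higher number from compound 1 to compound 3 (0.40 log units; beyond the scatter) as a modest step.

On these data alone, whether a methyl group or a hydroxyl group in place of amino would also keep the number low remains open. So does whether amino gives a similar step alongside trifluoromethyl.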